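The compounds below may be only part of what the source reports. "The series", "measured", "known", "first", "only" and "open" are said of these compounds alone.

Compound 1 `COc1ccc(CN(c2cc(OC)c(OC)c(OC)c2)S(=O)(=O)c2ccc(C)cc2)cc1` gives 4340 nM in a functional assay on MGC-803 cells (Homo sapiens) for inhibition, read by MTT assay, with a stated time of 48 h; on this read-out lower numbers stand for stronger inhibition and higher numbers for weaker inhibition. Compound 2 `COc1ccc(CN(c2cc(OC)c(OC)c(OC)c2)S(=O)(=O)c2ccccc2)cc1` reaches only a limit of this assay, > 50000 nM. Compound 3 `Cc1ccc(S(=O)(=O)N(Cc2nc3ccccc3[nH]2)c2ccccc2)cc1` gives 45200 nM in this assay.

Compound 1 and compound 2 differ in one place, (methyl in place of hydrogen on an aromatic carbon), and the step between them is an at least 11-fold lower number from compound 2 to compound 1 (1.06 log units; beyond the scatter). That step can only be given as a lower bound because compound 2 sits at the limit of > 50000 nM in this assay, at which 1 of the 3 values shown sits. How the core of compound 3 differs from that of compound 2 is not broken down here; the two values show that compound 3 and compound 1 lie a good distance apart, with compound 3 the higher of the two.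

Compound 4 `Cc1ccc(N(Cc2nc3ccccc3[nH]2)S(=O)(=O)c2ccc(C)cc2)cc1` has not yet been measured in this assay. It differs from compound 3 by methyl in place of hydrogen on an aromatic carbon, the same change that was made between compound 2 and compound 1, though the wider surroundings read differently: here it is phenyl to 4-methylphenyl alone, whereas in the earlier pair it also reads phenylsulfonyl to (4-methylphenyl)sulfonyl. On that basis compound 4 is expected to give a lower number than compound 3, with a step estimated as a 3.8-fold lower number from compound 3 to compound 4 (0.58 log units; beyond the scatter), smaller than the earlier one. The estimate for compound 4 is 12000 nM, with a range from 3000 nM to 40000 nM.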

Compound 4, half-maximal inhibitory concentration: 41300 nM
The estimate for compound 4 lay 3.4-fold (0.54 log units) below the measured number, and the stated range ends below it.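

In this assay, methyl in place of hydrogen on an aromatic carbon gives a 1.1-fold lower number from compound 3 to compound 4 (0.04 log units; within the scatter), so on this core the change leaves no mark that can be told from repeated measurement. The large effect seen on the core of compound 1 therefore did not carry over to the core of compound 3: the same change on two cores in this assay, an at least 11-fold lower number (1.06 log units; beyond the scatter) from compound 2 to compound 1 and a 1.1-fold lower number (0.04 log units; within the scatter) from compound 3 to compound 4, at least 10-fold (1.02 log units) apart, beyond the scatter of two such steps This shows that the size of the step depends on its surroundings in these two pairs, but not which difference between them is responsible, and the change itself also reads differently, as phenylsulfonyl to (4-methylphenyl)sulfonyl in the earlier pair and as phenyl to 4-methylphenyl alone in the new one.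

The compounds shown leave open whether methyl on the other aromatic ring of the core of compound 1 would give a similar result, and whether any third core would follow either pair. They also leave open whether a chlorine, an amine or a carboxylic acid in the place of that methyl, on an aromatic carbon para to a large group, would separate the two cores in the same way.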